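This account rests on a few compounds, and the source may have more. Where it says the series, first, only, none or still open, it means among the compounds named here.

Working notes on the series

The shared core is that of compound 1 `Cc1cc(C(=O)O)c(C)n1C`. In an assay on cells for inhibition of Palmitoleoyl-protein carboxylesterase NOTUM variant C330S (Homo sapiens), read by fluorescence, with a stated time of 40 min (on this read-out lower numbers stand for stronger inhibition and higher numbers for weaker inhibition), compound 1 gives only a limit of > 100000 nM (the limit of > 100000 nM in this assay, at which 1 of the 3 values shown sits). Compound 2 `COc1c(Cl)cccc1-n1c(C)cc(C(=O)O)c1C` gives 800 nM in this assay. Compound 3 `Cc1cc(C(=O)O)c(C)n1-c1cccc(Cl)c1C#N` gives 2000 nM in this assay, which is the highest of the two numbers that are not limits; the step of a 2.5-fold higher number from compound 2 to compound 3 (0.40 log units; beyond the scatter) separates it from compound 2, and that step is beyond the scatter.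

Compound 4 `Cc1cc(C(=O)O)c(C)n1-c1cccc(Cl)c1` is not yet measured. It differs from compound 3 by hydrogen in place of cyano on an aromatic carbon. Among the measured compounds shown here, the only measured step bearing on this aromatic carbon is a 2.5-fold higher number from compound 2 to compound 3 (0.40 log units; beyond the scatter), in which exchanging one group for another at that carbon moved the number by a modest amount. For the measured compounds named here, removing the group altogether has no direct precedent among the measured compounds, so the expectation rests on that single modest step and is correspondingly loose.

The step expected from this change is a 1.5-fold higher number from compound 3 to compound 4 (0.18 log units; within the scatter), a small loss at most. Compound 4 is therefore expected to give about 3000 nM in this assay, with a range of 1000 nM to 10000 nM.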

Compound 4, half-maximal inhibitory concentration: 430 nM
Compound 4: the middle estimate sits 7.0-fold (0.84 log units) above what was measured; measured number outside the range, below it.
By their numbers in this assay, from the lowest: compounds 4 and 2 (each within the scatter of the next); then compound 3. At a limit, above all of these: compound 1.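

Taking the cyano group off this aromatic carbon, ortho to a chloro group, gives a 4.7-fold lower number from compound 3 to compound 4 (0.67 log units; beyond the scatter) in this assay and shows that the cyano group is not needed for the inhibition seen in compound 3. Hydrogen in place of methoxy at the same carbon gives a 1.9-fold lower number from compound 2 to compound 4 (0.27 log units; within the scatter) and leaves the two compounds unseparated, so of the three groups shown at this carbon only cyano stands apart from the others. Nothing measured here gives a reason for the difference between cyano and hydrogen at this carbon.

From the compounds shown here alone, whether a fluoro group, a methyl group or an amine at this carbon would read like hydrogen and methoxy or like cyano remains open. Going by these compounds, the contribution of the chloro group to the inhibition also remains open.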